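A few compounds are considered here, and "the series" means these few. Any claim that something is new, unique, unknown or untested is made for them only; others in the source may bear on it.

Compound 1 `N#C/C(=C\c1ccoc1)C(=O)O` carries a carboxy group on the shared acrylonitrile-type arm, and in a functional assay on the whole organism (strain CD1) for inhibition, with Mus musculus as the target, with stated times of 15 min and 20 min, at a dose of 10 mg/kg by the subcutaneous route (a higher number here means more inhibition at the dose given (going by the name of the read-out), a lower number less inhibition), compound 1 gives 30.7%. Compound 2 `CCOC(=O)/C(C#N)=C/c1ccoc1` is the ethoxycarbonyl counterpart; in this assay compound 2 gives 55.9%. The change ethyl in place of hydrogen on an oxygen next to a carbonyl group thus made a number 25.2 percentage points higher from compound 1 to compound 2 (beyond the scatter). Compound 3 `N#C/C(=C\c1cc2ccccc2[nH]1)C(=O)O` keeps the carboxy arm on a different core; the difference between the two cores is not broken down here. In this assay compound 3 gives 25.8%, within the scatter of compound 1. Compound 4 `CCOC(=O)/C(C#N)=C/c1cc2ccccc2[nH]1` is not yet measured and differs from compound 3 by ethyl in place of hydrogen on an oxygen next to a carbonyl group, the same change that separates compound 1 from compound 2, seen once so far. The expected step is a number 20.2 percentage points higher from compound 3 to compound 4 (beyond the scatter), resting on a number 25.2 percentage points higher from compound 1 to compound 2 (beyond the scatter) in the first core. Compound 4 is estimated at 46%, from 28% to 64%.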

Compound 4, a percentage reported as inhibition, in the whole organism at one dose (the size of the read-out at that dose, not a potency): 88.4%
Compound 4: middle estimate off by 42.4 percentage points, on the low side; measured number outside the range, above it.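

In this assay, ethyl in place of hydrogen on an oxygen next to a carbonyl group gives a number 62.6 percentage points higher from compound 3 to compound 4 (beyond the scatter). The direction of the step carries over from one core to the other, but its size does not: the same change on two cores in this assay, a number 25.2 percentage points higher (beyond the scatter) from compound 1 to compound 2 and a number 62.6 percentage points higher (beyond the scatter) from compound 3 to compound 4, 37.4 percentage points apart, beyond the scatter of two such steps. This pair shows that a step read on one core need not give the size of the step on another, but it does not show which feature of the cores accounts for the gap or how the change would behave on a further core.

Still open, going by these compounds, is whether the step belongs to ethyl in particular or to any group replacing that hydrogen. A methyl group, a longer chain such as butyl, or an amide in place of the ethoxycarbonyl group would address this.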